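A few compounds are considered here, and "the series" means these few. Any claim that something is new, unique, unknown or untested is made for them only; others in the source may bear on it.

Working notes on the series. Compound 1 `CN(C)CC[C@H](CSc1ccccc1)Nc1ccc(S(=O)(=O)NC(=O)c2ccc(N3CCN(Cc4ccccc4)CC3)cc2)cc1[N+](=O)[O-]` carries a benzyl group on the piperazine; in a functional assay (FL5.12 cells, Mus musculus) with Apoptosis regulator Bcl-2 (Homo sapiens) as the target (a lower number here means that less compound is needed, a higher number that more compound is needed for the effect), compound 1 gives 1700 nM. Compound 2 `CN(C)CC[C@H](CSc1ccccc1)Nc1ccc(S(=O)(=O)NC(=O)c2ccc(N3CCN(Cc4ccccc4C(F)(F)F)CC3)cc2)cc1[N+](=O)[O-]` differs from it by a trifluoromethyl in place of hydrogen on an aromatic carbon, and in this assay compound 2 gives 130 nM. Among the measured compounds shown here, that single step, a 13-fold lower number from compound 1 to compound 2 (1.12 log units; beyond the scatter), is the only measured step in the set. On the numbers shown, compound 2 stands at the lowest of the two values, with compound 1 as its only neighbour at a step beyond the scatter.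

Compound 3 `CN(C)CC[C@H](CSc1ccccc1)Nc1ccc(S(=O)(=O)NC(=O)c2ccc(N3CCN(Cc4ccccc4-c4cccnc4)CC3)cc2)cc1[N+](=O)[O-]` is not yet measured. Relative to compound 2 the change is pyridin-3-yl in place of trifluoromethyl on an aromatic carbon. For the measured compounds named here, no measured step bears on this change directly: the one step seen concerns trifluoromethyl against hydrogen, not trifluoromethyl against a pyridin-3-yl ring, and it was large. The direction for compound 3 is therefore open; with the substituent kept ortho to a large group, the expectation is a modest loss relative to compound 2, carrying wide uncertainty, as a 1.9-fold higher number from compound 2 to compound 3 (0.28 log units; within the scatter). For compound 3 in this assay the estimate is 250 nM, with a range from 60 nM to 1000 nM.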

Compound 3, half-maximal effective concentration: 820 nM
Compound 3: the middle estimate sits 3.3-fold (0.52 log units) below what was measured; the measured number falls inside the stated range.
By their numbers in this assay, from the lowest: compound 2; then compound 3; then compound 1.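

Among the compounds shown here, at this position, on an aromatic carbon of a six-membered aromatic ring of carbon only and ortho to a large group, the result separates two substituents for the first time. In this assay, pyridin-3-yl does not hold what trifluoromethyl gives (a step of a 6.3-fold higher number from compound 2 to compound 3 (0.80 log units; beyond the scatter)), so the earlier gain does not carry over to any group placed here. Pyridin-3-yl still keeps part of that gain over hydrogen (a step of a 2.1-fold lower number from compound 1 to compound 3 (0.32 log units; beyond the scatter)), so both substituents seen at this position give a lower number than hydrogen, with no compound shown going against this, while the size of the fall depends on the group; nothing available gives a reason for this order.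

A plain phenyl at the same carbon would show whether the step from trifluoromethyl goes with the aromatic ring as such or with its ring nitrogen, and pyridin-2-yl or pyridin-4-yl would show whether the place of that nitrogen matters. A methyl, a chlorine or a nitrile at this carbon would show whether the order seen with the three compounds extends beyond hydrogen, trifluoromethyl and pyridin-3-yl.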